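A few compounds are considered here, and "the series" means these few. Any claim that something is new, unique, unknown or untested is made for them only; others in the source may bear on it.

Measured compounds:
- compound 1, `COc1cc(C(=O)N2CCC(CCN3CCC(C(=O)c4nc5ccccc5[nH]4)CC3)(c3ccccc3)C2)cc(OC)c1OC`: 7.44 nM
- compound 2, `COc1ccc(C2(CCN3CCC(C(=O)c4nc5ccccc5n4Cc4ccc(C(=O)O)cc4)CC3)CCN(C(=O)c3cc(OC)c(OC)c(OC)c3)C2)cc1OC`: 7 nM

Both numbers come from a functional assay for antagonist activity at Substance-P receptor (Cavia porcellus); on this read-out lower numbers stand for stronger inhibition and higher numbers for weaker inhibition. Compound 2 stands at the lowest of the two numbers shown, but the gap to compound 1, its nearest neighbour, lies within the scatter, so the two are not separated. Within the data shown here, no single-point step between measured compounds is available; the two values simply show that the differing parts of compound 1 and compound 2 leave the read-out unchanged.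

Compound 3, `COc1ccc(C2(CCN3CCC(C(=O)c4nc5ccccc5[nH]4)CC3)CCN(C(=O)c3cc(OC)c(OC)c(OC)c3)C2)cc1OC`, differs from compound 2 by hydrogen in place of 4-carboxybenzyl on an aromatic nitrogen. Compound 1 already carries hydrogen at that aromatic nitrogen and gives 7.44 nM, so the expectation for this step is no change beyond the scatter, no change at the digits printed from compound 2 to compound 3 (within the scatter). For compound 3 in this assay the estimate is 7 nM, with a range from 3 nM to 16 nM.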

Compound 3, half-maximal inhibitory concentration: 6.98 nM
Estimate against measurement, compound 3: 1.0-fold (0.00 log units) above; measured number inside the range.
By their numbers in this assay, from the lowest: compounds 3, 2 and 1 (each within the scatter of the next).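

In this assay the step from 4-carboxybenzyl to hydrogen on the aromatic nitrogen is a 1.0-fold lower number from compound 2 to compound 3 (0.00 log units; within the scatter) and so does not separate the two compounds; this position accepts either a bare hydrogen or the full 4-carboxybenzyl group at the same read-out. Compound 3 also links the other two compounds through single-place steps: 3,4-dimethoxyphenyl in place of phenyl on the saturated ring carbon gives a 1.1-fold lower number from compound 1 to compound 3 (0.03 log units; within the scatter) and likewise separates nothing. No measurement on hand accounts for either result.

Open, from the compounds shown here alone, is whether other groups on that aromatic nitrogen, such as methyl, plain benzyl or a longer chain ending in an amine, would also stay within the scatter of compound 3. Also open, going by these compounds, is whether a halogen or a single methoxy on that phenyl ring would read the same.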